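This account rests on a few compounds, and the source may have more. Where it says the series, first, only, none or still open, it means among the compounds named here.

Measured compounds and their values:
Compound 1, `COc1cc(-c2nn(-c3cccc(NC(=O)Nc4cc(C(F)(F)F)cc(C(F)(F)F)c4)c3)cc2-c2ccncc2)ccc1Cl`, gives 855 nM in a functional assay on HOP-62 cells (Homo sapiens) for inhibition, read by sulforhodamine B assay, with a stated time of 48 h; on this read-out higher numbers stand for weaker inhibition of growth and lower numbers for stronger inhibition of growth.
Compound 2, `COc1cc(-c2nn(-c3cccc(NC(=O)Nc4ccc(Cl)c(Cl)c4)c3)cc2-c2ccncc2)ccc1Cl`, gives 1440 nM.
Compound 3, `COc1cc(-c2nn(-c3cccc(NC(=O)Nc4cccc(C(F)(F)F)c4)c3)cc2-c2ccncc2)ccc1Cl`, gives 1340 nM.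

Compound 3 holds the second highest of the three numbers. Its nearest neighbour is compound 2 and its furthest is compound 1, and both gaps are within the scatter, so the three compounds cannot be told apart on these numbers.

Compound 4, `COc1cc(-c2nn(-c3cccc(NC(=O)c4ccc(Cl)c(C(F)(F)F)c4)c3)cc2-c2ccncc2)ccc1Cl`, arises from compound 3 by this change: 4-chloro-3-(trifluoromethyl)phenyl in place of (3-(trifluoromethyl)phenyl)amino on a carbonyl carbon. For the measured compounds named here, two measured steps bear on it, both at the same end of the molecule: a 1.6-fold higher number from compound 1 to compound 3 (0.20 log units; within the scatter) and a 1.1-fold lower number from compound 2 to compound 3 (0.03 log units; within the scatter). Both show that swapping substituents on the outer aromatic ring leaves the number within the scatter. Neither step, however, covers the loss of the amino part, which is the new element of compound 4, so the data give no guide for it. With this in mind, compound 4 is expected to sit close to compound 3, a step of a 1.0-fold higher number from compound 3 to compound 4 (0.02 log units; within the scatter) with no direction beyond the scatter, though with wider uncertainty. The estimate for compound 4 is 1400 nM, with a range from 500 nM to 4000 nM.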

Compound 4, concentration for 50% growth inhibition: 13100 nM
Beside the measured number, compound 4's estimate is 9.4-fold (0.97 log units) below it; measured number above the stated range.
By their numbers in this assay, from the lowest: compounds 1, 3 and 2 (each within the scatter of the next); then compound 4.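

Among compound 1, compound 2 and compound 3, changes to the substituents on the outer aromatic ring left the number in this assay within the scatter, which made this end of the molecule look tolerant. The amino nitrogen on the carbonyl carbon turns out to matter more, as its loss brings steps beyond the scatter, with a 9.8-fold higher number from compound 3 to compound 4 (0.99 log units; beyond the scatter) and a 9.1-fold higher number from compound 2 to compound 4 (0.96 log units; beyond the scatter), both toward weaker inhibition of growth. Nothing measured here explains this loss of activity.

The step also changes the outer ring, which gains a chlorine, so the effects of the amino nitrogen and the chlorine cannot be separated. Going by these compounds, it also remains open whether a methylene group or an oxygen atom in place of the amino nitrogen would keep the number near that of compound 3.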